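Carbamoyl for propoxy on the saturated ring

The source may hold more compounds than are shown below. What is called first, only, known or untested is meant among the compounds shown, and "the series" means these compounds.

Compound 2 `CCCOC1CCCN(CCCCOc2ccccc2/C=C/c2ccccc2)C1` gives 0% in a functional assay on the whole organism with Mus musculus as the target, in the maximal electroshock model, at a dose of 50 mg/kg by the oral route (on this read-out higher numbers stand for more inhibition at the one dose given (going by the name of the read-out) and lower numbers for less inhibition), level with compound 1 `CCCN(CCC)CCCCOc1ccccc1/C=C/c1ccccc1`, which in this assay gives 0%; the two values lie within the scatter. Compound 3 `NC(=O)C1CCCN(CCCCOc2ccccc2/C=C/c2ccccc2)C1` differs from compound 2 by carbamoyl in place of propoxy on a saturated ring carbon. Within the data shown here, no step between measured compounds exists to lean on. Because compound 1 gives 0% and compound 2 gives 0%, no step beyond the scatter is expected in this assay. For compound 3 the expected value is 5%, with a range from 0% to 25%. The expected step of a number 5 percentage points higher from compound 2 to compound 3 (within the scatter) is estimated to stay within the scatter.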

Compound 3, a percentage reported as inhibition, in the whole organism at one dose (the size of the read-out at that dose, not a potency): 0%
Compound 3: middle estimate off by 5 percentage points, on the high side; the measured number falls inside the stated range.
By their numbers in this assay, from the lowest: compounds 1, 2 and 3 (each within the scatter of the next).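

In this assay carbamoyl in place of propoxy on the saturated ring carbon gives no change at the digits printed from compound 2 to compound 3 (within the scatter), so a group with a hydrogen-bond donor stands level with one without. 3-Carbamoylpiperidin-1-yl in place of dipropylamino gives no change at the digits printed from compound 1 to compound 3 (within the scatter), so neither ring substituent separates from the open-chain amine. Nothing available bears on why these compounds read alike.

Open, on these data alone, is whether a carboxylic acid or an amine on this ring carbon would give a read-out beyond the scatter. Also open, as far as these compounds go, is whether a longer chain to the aromatic oxygen would do so.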